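The source may hold more compounds than are shown below. What is called first, only, known or untested is meant among the compounds shown, and "the series" means these compounds.

Measured in a functional assay on SK-MEL-28 cells (Homo sapiens) for inhibition, read by sulforhodamine B assay, with a stated time of 48 h; on this read-out lower numbers stand for stronger inhibition of growth and higher numbers for weaker inhibition of growth:
- compound 1 `COc1cc(-c2nn(-c3cccc(NC(=O)c4cccc(C(F)(F)F)c4)c3)cc2-c2ccncc2)ccc1Cl`: 2490 nM
- compound 2 `COc1cc(-c2nn(-c3cccc(NC(=O)c4ccc(Cl)c(C(F)(F)F)c4)c3)cc2-c2ccncc2)ccc1Cl`: 3080 nM

Compound 2 lies within the scatter of compound 1, so the two cannot be ranked. Compound 3 `COc1cc(-c2nn(-c3cccc(NC(=O)c4ccccc4)c3)cc2-c2ccncc2)ccc1Cl` is unmeasured and differs from compound 2 by phenyl in place of 4-chloro-3-(trifluoromethyl)phenyl on a carbonyl carbon. For the measured compounds named here, the one measured step that bears on this is a 1.2-fold higher number from compound 1 to compound 2 (0.09 log units; within the scatter), for chloro in place of hydrogen on an aromatic carbon. Going by the values given here, no measured step covers loss of the trifluoromethyl, so the expectation is loose. The expected change is a 1.0-fold lower number from compound 2 to compound 3 (0.01 log units; within the scatter), nothing beyond the scatter. For compound 3 the estimate is 3000 nM, with an expected range of 1200 nM to 8000 nM.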

Compound 3, concentration for 50% growth inhibition: 3860 nM
Compound 3: middle estimate off by 1.3-fold (0.11 log units), on the low side; the measured number falls inside the stated range.
By their numbers in this assay, from the lowest: compounds 1, 2 and 3 (each within the scatter of the next).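

In this assay the bare phenyl on the carbonyl carbon stays within the scatter of the 4-chloro-3-(trifluoromethyl)phenyl group (a 1.3-fold higher number from compound 2 to compound 3 (0.10 log units; within the scatter)) and also of the group with trifluoromethyl alone (a 1.6-fold higher number from compound 1 to compound 3 (0.19 log units; within the scatter)). Across compounds 1, 2 and 3, neither chloro nor trifluoromethyl therefore gives a readable step at this position. No measurement on hand accounts for this flat result. Still open, on these data alone, is whether an amine or a carboxylic acid on this phenyl would give a step beyond the scatter. As far as these compounds go, a longer chain in place of the phenyl on the carbonyl carbon is equally open.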